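From 2-methylphenyl to 3-methylpyridin-4-yl

This account rests on a few compounds, and the source may have more. Where it says the series, first, only, none or still open, it means among the compounds named here.

Values measured in a functional assay on MCF7 cells (Homo sapiens) for cytotoxicity, read by CellTiter-Glo, with a stated time of 5 days (on this read-out lower numbers stand for stronger inhibition and higher numbers for weaker inhibition), are as follows.

- compound 1 `CC/C(=C(/c1ccc(/C=C/C(=O)O)cc1)c1ccc2[nH]ncc2c1)c1ccccc1` gives 6 nM
- compound 2 `CC/C(=C(/c1ccc(/C=C/C(=O)O)cc1)c1ccc2[nH]ncc2c1)c1ccccc1C` gives 4 nM

On these two numbers, compound 2 cannot be told apart from compound 1. Among the compounds with values here, the one measured step is a 1.5-fold lower number from compound 1 to compound 2 (0.18 log units; within the scatter), and it adds a methyl group on an aromatic carbon.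

Compound 3 `CC/C(=C(/c1ccc(/C=C/C(=O)O)cc1)c1ccc2[nH]ncc2c1)c1ccncc1C` carries 3-methylpyridin-4-yl in place of 2-methylphenyl on a double-bonded chain carbon bound to a double-bonded chain carbon and a saturated chain carbon. Within the data shown here, the methyl step bears on this change only loosely, as no measured compound yet has a ring nitrogen here. With so little to go on, a modest move toward weaker inhibition in this assay is a cautious expectation, and the expected step is a 2.5-fold higher number from compound 2 to compound 3 (0.40 log units; beyond the scatter). For compound 3 the estimated value is 10 nM (expected range 3 nM to 30 nM).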

Compound 3, half-maximal inhibitory concentration: 16 nM
For compound 3 the middle estimate is 1.6-fold (0.20 log units) below the measured one, and the stated range covers the measured number.
By their numbers in this assay, from the lowest: compounds 2 and 1 (each within the scatter of the next); then compound 3.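

In this assay, within the data shown here, this is the first change at this position that moves the number beyond the scatter: replacing 2-methylphenyl with 3-methylpyridin-4-yl, which keeps the heavy-atom count and exchanges one ring carbon for a nitrogen, gives a 4.0-fold higher number from compound 2 to compound 3 (0.60 log units; beyond the scatter) and so a modest loss. Measured against the plain phenyl of compound 1, the change gives a 2.7-fold higher number from compound 1 to compound 3 (0.43 log units; beyond the scatter) and is again modest, so a position that showed no readable response to a methyl group does respond to this methylpyridine ring. Nothing available gives a reason for this rise.

The compounds shown leave open whether plain pyridin-4-yl, without the methyl group, would behave like 3-methylpyridin-4-yl. They also leave open whether a chlorine or a methoxy group in place of that methyl would move the number in either direction.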